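This account rests on a few compounds, and the source may have more. Where it says the series, first, only, none or still open, it means among the compounds named here.

Measured compounds:
compound 1 `C[C@@H](Nc1nccc(Cl)c1NC(=O)CC#N)c1ccc(-c2cccc(F)c2C#N)cc1` — "not determined" (no result reported) in an in vivo ADME assay on the whole organism for pharmacokinetics, with Canis familiaris (Canis lupus familiaris) as the target, at a dose of 1 mg/kg by the intravenous route; a higher number here means faster removal of the compound, a lower number slower removal
compound 2 `C[C@@H](Nc1nccc(Cl)c1NC(=O)CC#N)c1ccc(-c2cccc(F)c2C(F)(F)F)cc1` — "not determined" (no result reported) in this assay
compound 3 `Cc1noc(-c2c(F)cccc2-c2ccc([C@@H](C)Nc3nccc(Cl)c3NC(=O)CC#N)cc2)n1` — 7.3 mL/min/kg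

Compound 3 holds the only number shown in this assay; compound 1 and compound 2 carry no result there, so nothing can be said of how they compare with it. Compound 4 `C[C@@H](Nc1nccc(Cl)c1NC(=O)CC#N)c1ccc(-c2cccc(F)c2-c2nnn(C)n2)cc1` has not yet been measured. It differs from compound 3 in one place: 2-methyl-2H-tetrazol-5-yl in place of 3-methyl-1,2,4-oxadiazol-5-yl on an aromatic carbon. Among the compounds with values here, no step between measured compounds gives a guide to this kind of exchange, so the expected step of a 1.0-fold higher number from compound 3 to compound 4 (0.01 log units; within the scatter) is one that stays within the usual scatter, in neither direction. Compound 4 is accordingly estimated at 7.5 mL/min/kg, with a range from 3.5 mL/min/kg to 16 mL/min/kg.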

Compound 4, clearance: 2.4 mL/min/kg
Beside the measured number, compound 4's estimate is 3.1-fold (0.49 log units) above it, and the stated range ends above it.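

Within the data shown here, on an aromatic carbon ortho to a fluoro group, 2-methyl-2H-tetrazol-5-yl in place of 3-methyl-1,2,4-oxadiazol-5-yl gives a 3.0-fold lower number from compound 3 to compound 4 (0.48 log units; beyond the scatter) in this assay, the first readable step at this position. Clearance at this place therefore responds to the choice between these two five-membered aromatic rings, although both groups have the same heavy-atom count. Nothing measured here accounts for the change.

As far as these compounds go, whether a 1,3,4-oxadiazole or a primary amide at this place would follow compound 4 or compound 3 stays open, as does the effect of the same exchange on any other part of the shared core.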